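A few compounds are considered here, and "the series" means these few. Any claim that something is new, unique, unknown or untested is made for them only; others in the source may bear on it.

Compound 1 `COc1ccc(-c2cn3ccnc3c(-c3ccc4ncn(C5CCCCC5)c4c3)n2)cc1`: 62.2%
Compound 2 `O=Cc1ccc(-c2cn3ccnc3c(-c3ccc4ncn(C5CCCCC5)c4c3)n2)cc1`: 54.5%

In a functional assay on NCI-H23 cells (Homo sapiens) for inhibition, read by sulforhodamine B assay, with a stated time of 48 h, tested at 10 uM (on this read-out lower numbers stand for less inhibition and higher numbers for more inhibition at the one concentration tested (going by the name of the read-out)), compound 1 gives 62.2%, and compound 2 gives 54.5%. Compound 2 stands at the lower end of these two numbers, its nearest neighbour being compound 1, but the step of a number 7.7 percentage points lower from compound 1 to compound 2 (within the scatter) lies within the scatter, so the two measured compounds cannot be told apart on this read-out.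

Compound 3 `c1ccc2c(-c3cn4ccnc4c(-c4ccc5ncn(C6CCCCC6)c5c4)n3)cccc2c1` has not yet been measured. It differs from compound 2 in one place: naphthalen-1-yl in place of 4-formylphenyl on an aromatic carbon. Among the measured compounds shown here, the only measured step available, a number 7.7 percentage points lower from compound 1 to compound 2 (within the scatter), exchanges methoxy for formyl on an aromatic carbon and leaves the read-out within the scatter. That step does not cover the exchange of a whole 4-formylphenyl for naphthalen-1-yl, so the two measured compounds give no direct guide to the size or direction of the change to compound 3.

For the measured compounds named here, with no measured step bearing on it, the step of a number 0.5 percentage points higher from compound 2 to compound 3 (within the scatter) is expected to stay small, with a wide uncertainty. Compound 3 is therefore estimated at 55%, within a range from 30% to 80%.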

Compound 3, a percentage reported as inhibition, at one concentration (the size of the read-out at that concentration, not a potency): 4.32%
Compound 3: the middle estimate sits 50.7 percentage points above what was measured; measured number outside the range, below it.
By their numbers in this assay, from the lowest: compound 3; then compounds 2 and 1 (each within the scatter of the next).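

In this assay, the aromatic carbon next to the ring nitrogen proves sensitive to what it carries: a number 50.2 percentage points lower from compound 2 to compound 3 (beyond the scatter) with naphthalen-1-yl in place of 4-formylphenyl, and a number 57.9 percentage points lower from compound 1 to compound 3 (beyond the scatter) with naphthalen-1-yl in place of 4-methoxyphenyl. The earlier exchange of methoxy for formyl stayed within the scatter and changed only the group on the phenyl ring, whereas these two large steps replace the whole group on this carbon and run in the same direction, whichever 4-substituted phenyl group leaves. Nothing available offers an explanation for this drop.

The compounds shown leave open whether the loss goes with the second aromatic ring of naphthalen-1-yl or with the departure of the oxygen-bearing group, and an unsubstituted phenyl at this carbon would separate those two readings. They also leave open how naphthalen-2-yl would read here, and whether a 4-aminophenyl or a 4-carboxyphenyl would stay level with compound 1 and compound 2.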